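Swapping Phenyl for Thiophene in a Cytotoxicity Series

The source may report more compounds than this note shows. Statements on the series, on what has been measured and on what is new or still open speak of the compounds shown alone.

Measured so far:
- Compound 1 `COc1ccc(C2=C(c3ccccc3)C(=O)N3CCCC3C2)cc1` gives 390 nM in a functional assay on HCT-116 cells (Homo sapiens) for cytotoxicity; on this read-out higher numbers stand for weaker inhibition and lower numbers for stronger inhibition
- Compound 2 `CSc1ccc(C2=C(c3ccccc3)C(=O)N3CCCC3C2)cc1` gives 1000 nM in this assay

Both compounds share the same core and differ only in one group on the aromatic ring: the step of a 2.6-fold higher number from compound 1 to compound 2 (0.41 log units; beyond the scatter) shows that methylsulfanyl in place of methoxy weakens inhibition by a modest margin. For the measured compounds named here, on the numbers in hand, compound 2 therefore has the highest number of the two, and the only neighbour, compound 1, stands at a lower number.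

Compound 3 `CSc1ccc(C2=C(c3cccs3)C(=O)N3CCCC3C2)cc1` keeps the methylsulfanyl group of compound 2 and changes the other aromatic group: thiophen-2-yl in place of phenyl on a double-bonded ring carbon. Going by the values given here, no measured step in this set involves this kind of exchange; the single step recorded concerns a different position and a different pair of groups, so it gives no direct guide. Without a comparable step, the expectation is that the number stays about where compound 2 lies, and the estimated step of no change at the digits printed from compound 2 to compound 3 (within the scatter) is expected to fall within the scatter. For compound 3 the expected value in this assay is 1000 nM, with a range from 300 nM to 3200 nM.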

Compound 3, half-maximal inhibitory concentration: 270 nM
Estimate against measurement, compound 3: 3.7-fold (0.57 log units) above, outside the stated range (below it).
By their numbers in this assay, from the lowest: compounds 3 and 1 (each within the scatter of the next); then compound 2.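

In this assay, the step of a 3.7-fold lower number from compound 2 to compound 3 (0.57 log units; beyond the scatter) shows that the aromatic group on the double-bonded ring carbon matters to the result: thiophen-2-yl, a five-membered aromatic ring with one sulfur atom, gives stronger inhibition than phenyl. For the compounds shown here, the only earlier step, a 2.6-fold higher number from compound 1 to compound 2 (0.41 log units; beyond the scatter), concerned the other aromatic group and went towards weaker inhibition, so this is the first sign that a second place on the molecule can move the number, and that it can do so towards stronger inhibition. No measurement available here bears on why the exchange has this effect, so it stands as an observation only.

As far as these compounds go, it remains open whether the same exchange would act in the same way with methoxy in place of methylsulfanyl, and so whether the effects of the two places simply add up. From the compounds shown here alone, it is also open how other groups on this carbon would compare, for example thiophen-3-yl, furan-2-yl, a pyridine ring or a small methyl group, and whether the sulfur-containing ring is needed at all.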